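A few compounds are considered here, and "the series" means these few. Any claim that something is new, unique, unknown or untested is made for them only; others in the source may bear on it.

Among the measured compounds shown here, in a functional assay on L1210 cells (Mus musculus) for inhibition (a lower number here means a stronger inhibitor, a higher number a weaker inhibitor), compound 1 (`CC(C)CN(NC(=O)OCc1ccccc1)C(=O)CN(Cc1ccccc1)NC(=O)Cc1cccc(Br)c1`) gives 30000 nM, the higher of the two numbers so far, which makes it the weaker inhibitor of the pair. Compound 2 (`CC(C)CN(CC(=O)N(CC(C)C)NC(=O)OCc1ccccc1)NC(=O)CNNC(=O)CBr`) gives 7600 nM. Compound 3 (`CC(C)CN(NC(=O)OCc1ccccc1)C(=O)CN(Cc1ccccc1)/N=C/c1ccccc1B(O)O`) keeps the core of compound 1 and changes one part: a group of 11 heavy atoms (7 carbon, 1 boron, 1 nitrogen, 2 oxygen; one six-membered aromatic ring of carbon only) in place of a group of 11 heavy atoms (8 carbon, 1 nitrogen, 1 oxygen, 1 bromine; one six-membered aromatic ring of carbon only), on an amine nitrogen. For the measured compounds named here, no measured pair shows this change, so the expectation is loose: a moderate step towards stronger inhibition, resting only on compound 2 at 7600 nM showing that this series can reach lower numbers. The estimate is a 2.5-fold lower number from compound 1 to compound 3 (0.40 log units; beyond the scatter), an expected change only. For compound 3, the expected value is 12000 nM, within an estimated range of 3000 nM to 50000 nM.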

Compound 3, half-maximal inhibitory concentration: 27900 nM
Beside the measured number, compound 3's estimate is 2.3-fold (0.37 log units) below it, within the range that was stated.
By their numbers in this assay, from the lowest: compound 2; then compounds 3 and 1 (each within the scatter of the next).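

On an amine nitrogen of the shared core, putting the boron-containing group in place of the bromine-containing group gives a 1.1-fold lower number from compound 1 to compound 3 (0.03 log units; within the scatter) in this assay. At this position, then, the two groups of 11 heavy atoms, each with one six-membered aromatic ring of carbon only, cannot be told apart, although the entering group has more hydrogen-bond donors and acceptors. Nothing measured on these compounds explains this result.

Going by these compounds, whether a carboxylic acid or an amine at this place would give a different number remains open. Compound 2 differs from compound 1 and compound 3 in more than one place, so it cannot settle this.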